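One Group Exchanged on a Carbonyl Carbon

The source may report more compounds than this note shows. Statements on the series, on what has been measured and on what is new or still open speak of the compounds shown alone.

Of the compounds shown here, two built on the same core have been measured so far. In a physicochemical assay for solubility, at pH 7.4 (a higher number here means a more soluble compound, a lower number a less soluble compound), compound 1 `O=C(N[C@H]1CN(S(=O)(=O)c2ccccc2)C[C@@H]1C(=O)N[C@H]1CCCNC1)c1cc(C2CC2)n[nH]1` gives 861000 nM, the higher of the two numbers. Compound 2 `Cc1nc(-c2cccc(C(F)(F)F)c2)sc1C(=O)N[C@H]1CN(S(=O)(=O)c2ccccc2)C[C@@H]1C(=O)N[C@H]1CCCNC1` gives 112000 nM, which is lower by more than the scatter of repeated measurements.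

Attention now turns to compound 3 `O=C(N[C@H]1CN(S(=O)(=O)c2ccccc2)C[C@@H]1C(=O)N[C@H]1CCCNC1)c1cc(-c2ccccc2Cl)on1`, which has not yet been measured. It departs from compound 1 at a single place, on a carbonyl carbon, where the 3-cyclopropyl-1H-pyrazol-5-yl group leaves: a group of 12 heavy atoms (9 carbon, 1 nitrogen, 1 oxygen, 1 chlorine; one five-membered aromatic ring with 2 hetero atoms, one six-membered aromatic ring of carbon only) in place of a group of 8 heavy atoms (6 carbon, 2 nitrogen; one three-membered non-aromatic ring of carbon only, one five-membered aromatic ring with 2 hetero atoms), on a carbonyl carbon.

Within the data shown here, no pair of measured compounds differs in one place only, so the data offer no direct precedent for this exchange. The expectation therefore rests on the spread of the two numbers, with compound 2 at 112000 nM as the only lower reference. A downward step in this assay, beyond the scatter, is expected, and its estimated size is a 3.4-fold lower number from compound 1 to compound 3 (0.54 log units; beyond the scatter). The expected value for compound 3 is 250000 nM, with an estimated range from 90000 nM to 650000 nM.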

Compound 3, solubility: 12000 nM
Compound 3: middle estimate off by 21-fold (1.32 log units), on the high side; the whole stated range lies above it.
By their numbers in this assay, from the lowest: compound 3; then compound 2; then compound 1.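

In this assay, among these compounds, the exchange on the carbonyl carbon gives the first step between compounds that differ in one place: a 72-fold lower number from compound 1 to compound 3 (1.86 log units; beyond the scatter) is a large step, and it lies beyond the scatter. It shows that a change at this one position, with the shared core left as it is, can by itself move the read-out a long way. It also ties a much lower number to the entering group, which has 12 heavy atoms, 0 hydrogen-bond donors and 2 hydrogen-bond acceptors, in place of 3-cyclopropyl-1H-pyrazol-5-yl, with 8 heavy atoms, 1 hydrogen-bond donor and 1 hydrogen-bond acceptor; no measurement at hand speaks to the origin of this drop.

The chlorine, the six-membered aromatic ring of carbon only and the change in the five-membered aromatic ring all arrive together, so the compounds shown leave open which of them goes with the step. They also leave open how a group carrying an amine or a carboxylic acid would read at this carbonyl carbon.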